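This account rests on a few compounds, and the source may have more. Where it says the series, first, only, none or still open, it means among the compounds named here.

Of the compounds shown here, three have been measured in a functional assay on MCF7 cells (Homo sapiens) for cytotoxicity, read by MTT assay, with a stated time of 72 h; a higher number here means a weaker inhibitor of growth, a lower number a stronger inhibitor of growth. Compound 2 `C[Se]/C(=N\C(=O)c1cccs1)NC(=O)c1cccs1` gives 5640 nM, the lowest number of the three and so the strongest growth inhibitor among them. Compound 1 `CS/C(=N\C(=O)c1sccc1Cl)NC(=O)c1sccc1Cl` gives 57100 nM and compound 3 `C[Se]/C(=N\C(=O)c1ccno1)NC(=O)c1ccno1` gives 57500 nM; each of these numbers lies higher than that of compound 2 by a margin beyond the usual scatter, so compound 2 stands alone at the low end. Compound 1 and compound 3 each differ from compound 2 in more than one place, so neither pair isolates a single change.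

Compound 4 `CS/C(=N\C(=O)c1cccs1)NC(=O)c1cccs1` has not yet been measured. It differs from compound 2 in one place: a group of 2 heavy atoms (1 carbon, 1 sulfur; no ring) in place of a group of 2 heavy atoms (1 carbon, 1 selenium; no ring), on a carbon with a double bond to nitrogen. Compound 1 carries the same methylsulfanyl group and gives a high number, but it differs from compound 4 elsewhere as well, so that comparison shows only what the two values show. With no single-change step of this kind in the measured set, the size of the change is uncertain; the expectation is a step toward a higher number in this assay, of a 3.5-fold higher number from compound 2 to compound 4 (0.55 log units; beyond the scatter), beyond the scatter. The estimated value for compound 4 is 20000 nM, with a range from 5000 nM to 80000 nM.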

Compound 4, concentration for total growth inhibition: 89000 nM
Compound 4: middle estimate off by 4.5-fold (0.65 log units), on the low side; measured number above the stated range.
By their numbers in this assay, from the lowest: compound 2; then compounds 1, 3 and 4 (each within the scatter of the next).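

Among the compounds shown here, the pair of compound 2 and compound 4 is the first in this set to isolate a single change: in this assay, replacing the selenium-bearing group with methylsulfanyl, on a carbon with a double bond to nitrogen, gives a 16-fold higher number from compound 2 to compound 4 (1.20 log units; beyond the scatter). With the rest of the structure held fixed, this position clearly does not treat the two groups alike, and the selenium-bearing group goes with the stronger growth inhibition, so the low number of compound 2 is tied to this group and not to the shared core alone. Nothing in the data at hand shows what lies behind a step of this size.

As far as these compounds go, whether the step holds on other cores remains open, since compound 3 carries the selenium-bearing group and still gives 57500 nM, and neither it nor compound 1 has a partner here that differs by this one change. The compounds shown also say nothing about how a methoxy group, an amine or a longer chain would fare on the same carbon.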